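The source may report more compounds than this note shows. Statements on the series, on what has been measured and on what is new or still open speak of the compounds shown alone.

Of the compounds shown here, three built on the same core have been tested in a functional assay on PC-3 cells (Homo sapiens) for antiproliferative activity, read by MTT assay, with a stated time of 24 h; a higher number here means a weaker inhibitor, a lower number a stronger inhibitor. Compound 1 `CCn1c(C(=O)NCCC(=O)OC)ccc1C(CC)(CC)c1ccc(OCS(=O)(=O)c2ccccc2)c(C)c1` gives 40400 nM. Compound 2 `CCn1c(C(=O)NCCNC(=O)OC(C)(C)C)ccc1C(CC)(CC)c1ccc(OCS(=O)(=O)c2ccccc2)c(C)c1` returns only a limit of the assay, > 50000 nM. Compound 3 `CCn1c(C(=O)N[C@H](CO)CCCO)ccc1C(CC)(CC)c1ccc(OCS(=O)(=O)c2ccccc2)c(C)c1` gives 6810 nM, the lowest of the two numbers shown; its nearest neighbour is compound 1, and the step of a 5.9-fold lower number from compound 1 to compound 3 (0.77 log units; beyond the scatter) lies beyond the scatter. The step of an at least 7.3-fold lower number from compound 2 to compound 3 (0.86 log units; beyond the scatter) is also at least modest, whereas an at least 1.2-fold higher number from compound 1 to compound 2 (0.09 log units; that floor lies within the scatter) sits at a floor inside the scatter. All three differ only in the group carried on the amide-type nitrogen, so that group clearly moves the number.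

Compound 4 `CCn1c(C(=O)N[C@H](CC(=O)O)C(=O)O)ccc1C(CC)(CC)c1ccc(OCS(=O)(=O)c2ccccc2)c(C)c1` changes the same position again: a group of 8 heavy atoms (4 carbon, 4 oxygen; no ring) in place of a group of 7 heavy atoms (5 carbon, 2 oxygen; no ring), on an amide-type nitrogen. The two steps that end at compound 3 are the ones that bear on this change, and both were modest or larger, so a step beyond the scatter is plausible here too. Neither measured chain resembles a 1,2-dicarboxyethyl group, so the direction is uncertain; a modest rise is expected, a 2.2-fold higher number from compound 3 to compound 4 (0.34 log units; beyond the scatter). Compound 4 is therefore estimated at 15000 nM, with a range from 4000 nM to 60000 nM.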

Compound 4, half-maximal inhibitory concentration: > 50000 nM
Compound 4 gave a limit, no number; the forecaster's own chance of this, stated with the estimate: 20%; middle value at least 3.3-fold (0.52 log units) from the limit.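

Compound 4 returns a limit of the assay rather than a number, so this position is now seen to drop back as well as improve. The step of an at least 7.3-fold higher number from compound 3 to compound 4 (0.86 log units; beyond the scatter) shows that putting 1,2-dicarboxyethyl in place of the group of 7 heavy atoms on the amide-type nitrogen is enough to lose the lower number, even though the counts of hydrogen-bond donors and acceptors computed for the two groups are the same, so those counts alone do not follow the result at this position. The other readable step is an at least 1.2-fold higher number from compound 1 to compound 4 (0.09 log units; that floor lies within the scatter), a floor that lies inside the scatter, and across the four compounds only the group of compound 3 gives a number beyond the scatter from all the others.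

The compounds shown leave open whether a chain with a single carboxylic acid, an amine, or a longer chain ending in a hydroxyl group would stay near compound 3 or fall away as compound 4 does. Compound 2 and compound 4 cannot be ordered, and the step between them cannot be read: the limit of > 50000 nM in this assay, at which 2 of the 4 values shown sit.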